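Swapping phenyl for pyridin-2-yl on a lactone core

This account rests on a few compounds, and the source may have more. Where it says the series, first, only, none or still open, it means among the compounds named here.

Compound 1 `CCOC(=O)C12C(=O)OCC=C1COC2c1ccccc1` gives > 1000000 nM in a functional assay on QGY cells (Homo sapiens) for cytotoxicity, read by MTT assay (a higher number here means a weaker inhibitor, a lower number a stronger inhibitor), a limit of the assay rather than a number.
Compound 2 `CCOC(=O)C12C(=O)OCC=C1COC2c1ccc(C(C)(C)C)cc1` gives > 1000000 nM in this assay, again a limit.
Compound 3 `CCOC(=O)C12C(=O)OCC=C1COC2c1cc(OC)cc(OC)c1` gives > 1000000 nM in this assay, also a limit.

All three measured compounds share the same core and differ only in the aromatic group attached to it. Going by the values given here, compound 1 sits at the limit of this assay, and so do the two other values shown, which means no compound here has a readable number. Among the compounds with values here, the one step between neighbours that differ in a single place, a step that the two limits leave unreadable from compound 1 to compound 2, cannot be sized for this reason, as the limit of > 1000000 nM in this assay, at which 3 of the 3 values shown sit, shows.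

Compound 4 `CCOC(=O)C12C(=O)OCC=C1COC2c1ccccn1` is not yet measured. It differs from compound 1 in this way: pyridin-2-yl in place of phenyl on a saturated ring carbon. Since every measured value stands at the same limit, there is no readable step to draw on; the only pattern is that three aromatic variations all leave the compound inactive. The step from compound 1 to compound 4 is therefore expected to be none beyond the scatter, that is a number no higher from compound 1 to compound 4 (the limit leaves the size open). The estimate for compound 4 is 1000000 nM, with an expected range from 300000 nM to 3000000 nM, and most likely the assay will again report only a limit.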

Compound 4, half-maximal inhibitory concentration: > 1000000 nM
Compound 4 ended at the assay's limit (the forecaster's own chance of this, stated with the estimate: 85%); the middle value lies on the limit itself.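

Compound 4 gives no readable step from compound 1, since both end at a limit of the assay rather than a number, and the effect of pyridin-2-yl in place of phenyl cannot be sized: the limit of > 1000000 nM in this assay, at which 4 of the 4 values shown sit.

The compounds shown leave open whether any change to the shared core or its aromatic group would give a readable number in this assay.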